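This account rests on a few compounds, and the source may have more. Where it says the series, first, only, none or still open, it means among the compounds named here.

Compound 1 `O=C(CC(c1ccccc1)c1ccccc1)N1CCN(C(c2ccccc2)c2cccc(Cl)c2)CC1`: 582 nM
Compound 2 `O=C(NC(c1ccccc1)c1ccccc1)N1CCN(C(c2ccccc2)c2ccccc2)CC1`: 292 nM

In an in vivo ADME assay on the whole organism (strain Sprague-Dawley) for pharmacokinetics, with Rattus norvegicus as the target, at a dose of 10 mg/kg by the oral route (on this read-out lower numbers stand for lower exposure and higher numbers for higher exposure at the dose given), compound 1 gives 582 nM and compound 2 gives 292 nM. These two numbers lie within the usual scatter of each other, so compound 1 cannot be ranked apart from compound 2.

Compound 3 `O=C(CC(c1ccccc1)c1ccccc1)N1CCN(C(c2ccccc2)c2cccc(C(F)(F)F)c2)CC1` keeps the core of compound 1 and differs in one place: trifluoromethyl in place of chloro on an aromatic carbon. In words, trifluoromethyl stands in place of chloro on an aromatic carbon, turning 3-chlorophenyl into 3-(trifluoromethyl)phenyl. Among the compounds with values here, no pair of measured compounds shows this change, so the data offer no direct guide to its size or direction. The best anchor is compound 1 at 582 nM. The expected step, a 1.2-fold lower number from compound 1 to compound 3 (0.07 log units; within the scatter), stays within the scatter, with no firm direction. For compound 3 the estimated value is 500 nM, within an expected range of 170 nM to 1400 nM.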

Compound 3, maximal plasma concentration: 518 nM
Beside the measured number, compound 3's estimate is 1.0-fold (0.02 log units) below it, within the range that was stated.
By their numbers in this assay, from the lowest: compounds 2, 3 and 1 (each within the scatter of the next).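

In this assay, putting trifluoromethyl in place of chloro on this aromatic carbon gives a 1.1-fold lower number from compound 1 to compound 3 (0.05 log units; within the scatter) and so no change that stands clear of the usual scatter, even with four heavy atoms entering where one leaves. Within the data shown here, compound 1 and compound 3 form the first pair here that differs in one place, so this is the first direct reading of any single change, which compound 2 could not offer. Nothing measured here bears on this result.

Still open, from the compounds shown here alone, is how an amine, a carboxylic acid or a nitrile would read on the same aromatic carbon; both groups seen so far have no hydrogen-bond donors, no hydrogen-bond acceptors and no net charge. Also open, going by these compounds, is whether this swap reads the same way on another core, since this single pair is the only record of it.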